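The compounds below may be only part of what the source reports. "The series", "measured", "known", "first", "only" and "open" are said of these compounds alone.

Compound 1 `COc1ccccc1-n1cc(CN2C(=O)C[C@@H]3CC[C@@]2(C)C3(C)C)nn1` gives 350 nM 
Compound 2 `Cc1ccc(-n2cc(CN3C(=O)C[C@@H]4CC[C@@]3(C)C4(C)C)nn2)cc1` gives 400 nM 

In a functional assay on A549 cells (Homo sapiens) for inhibition, read by MTT assay, with a stated time of 24 h (on this read-out higher numbers stand for weaker inhibition and lower numbers for stronger inhibition), compound 2 stands level with compound 1 within the scatter, as a 1.1-fold higher number from compound 1 to compound 2 (0.06 log units; within the scatter) shows. Compound 3 `COc1cccc(-n2cc(CN3C(=O)C[C@@H]4CC[C@@]3(C)C4(C)C)nn2)c1` differs from compound 2 by 3-methoxyphenyl in place of 4-methylphenyl on an aromatic nitrogen on an aromatic nitrogen. Among the measured compounds shown here, the one measured step at this place is a 1.1-fold higher number from compound 1 to compound 2 (0.06 log units; within the scatter) and it also exchanges 4-methylphenyl and a methoxyphenyl, so no step beyond the scatter is expected in this assay here. The expected step is a 1.1-fold lower number from compound 2 to compound 3 (0.02 log units; within the scatter) in size. Compound 3 is estimated at 380 nM within an expected range from 170 nM to 850 nM overall.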

Compound 3, half-maximal inhibitory concentration: 240 nM
For compound 3 the middle estimate is 1.6-fold (0.20 log units) above the measured one; low and high end bracket the measured number.
By their numbers in this assay, from the lowest: compounds 3, 1 and 2 (each within the scatter of the next).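

In this assay, 3-methoxyphenyl on the aromatic nitrogen stands level with 4-methylphenyl (a 1.7-fold lower number from compound 2 to compound 3 (0.22 log units; within the scatter)) and with 2-methoxyphenyl (a 1.5-fold lower number from compound 1 to compound 3 (0.16 log units; within the scatter)). All three aryl groups now lie within the scatter of one another, and moving from 2-methoxyphenyl to 3-methoxyphenyl gives no separable difference. Nothing available bears on why these groups stand level. Still open, from the compounds shown here alone, is whether a phenyl carrying an amine or a carboxylic acid, or a longer alkyl chain in place of the aryl group, would stay at this level.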